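Isobutyl amide series: adding chloro to the aromatic ring

A few compounds are considered here, and "the series" means these few. Any claim that something is new, unique, unknown or untested is made for them only; others in the source may bear on it.

Three compounds of this series have numbers in an assay on cell membranes for displacement of a labelled ligand from Cholecystokinin receptor type A (Rattus norvegicus), read by CCK-8 assay, with a stated time of 2 h; a higher number here means a weaker inhibitor, a lower number a stronger inhibitor. Compound 3 `CC(C)CN1C(=O)C=C(Cl)C1(O)c1ccccc1` gives 20 nM, the lowest of the three. Among the compounds with values here, compound 1 `CN1C(=O)C=C(Cl)C1(O)c1ccc(Cl)cc1` gives 2000 nM, and compound 2 `O=C1C=C(Cl)C(O)(c2ccc(Cl)cc2)N1C1CC1` gives 4000 nM; the one measured step, a 2.0-fold higher number from compound 1 to compound 2 (0.30 log units; within the scatter), lies within the scatter. Compound 3 stands apart from both: compound 1 and compound 2 each have a higher number, both gaps beyond the scatter, but compound 3 differs from each of them in two places at once, so neither gap can be assigned to a single change.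

Compound 4 `CC(C)CN1C(=O)C=C(Cl)C1(O)c1ccc(Cl)cc1` is compound 3 with chloro in place of hydrogen on an aromatic carbon. Within the data shown here, no measured pair differs only at this place on the six-membered aromatic ring of carbon only, so no step among the three bears directly on the change; the step from compound 1 to compound 2 concerns the nitrogen and not the ring. The expectation for this assay is therefore no step beyond the scatter, a 1.5-fold higher number from compound 3 to compound 4 (0.18 log units; within the scatter), since compound 3 with 20 nM is the only anchor. Compound 4 is estimated at 30 nM, with a range from 8 nM to 120 nM.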

Compound 4, half-maximal inhibitory concentration: 8 nM
Compound 4: middle estimate off by 3.8-fold (0.57 log units), on the high side, within the range that was stated.
By their numbers in this assay, from the lowest: compound 4; then compound 3; then compounds 1 and 2 (each within the scatter of the next).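

In this assay, within the data shown here, chloro in place of hydrogen on an aromatic carbon, para to a large group, gives a 2.5-fold lower number from compound 3 to compound 4 (0.40 log units; beyond the scatter) and is the first reading of this ring position through a single change: with isobutyl on the nitrogen, the position takes chloro with a modest but real gain. With chloro held on the ring, the nitrogen group can now also be read one change at a time: isobutyl in place of cyclopropyl gives a 500-fold lower number from compound 2 to compound 4 (2.70 log units; beyond the scatter) and isopropyl in place of hydrogen on the saturated chain carbon gives a 250-fold lower number from compound 1 to compound 4 (2.40 log units; beyond the scatter), so among these compounds both steps at the nitrogen are large and the step on the ring is modest. No measured evidence on the origin of either effect is available here.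

The compounds shown leave open whether the gain from chloro carries over to the methyl and cyclopropyl amides, since only the isobutyl pair reads that change. They also leave open how bromo, methoxy or a nitrile at the same ring position would compare with chloro, and how a longer chain such as n-pentyl on the nitrogen would compare with isobutyl.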